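Configuration at the stereocentre: compound 3 to compound 4

A few compounds are considered here, and "the series" means these few. Any claim that something is new, unique, unknown or untested is made for them only; others in the source may bear on it.

Measured so far in a toxicity assay on Huh-7.5 cells (Homo sapiens) for cytotoxicity, read by MTT assay, with a stated time of 96 h; a higher number here means that more compound is tolerated, a lower number that less compound is tolerated:
- compound 1 `N#Cc1ccc(NCCCn2ccnc2)cc1CN1CCN(C(c2ccc(F)cc2)c2ccc(F)cc2)CC1` gives 5890 nM
- compound 2 `CN(C)CCN(C)c1ccc(C#N)c(CN2CCN(C(c3ccc(Cl)cc3)c3ccc(Cl)cc3)CC2)c1` gives 3330 nM
- compound 3 `CN(C)CCN(C)c1ccc(C#N)c(CN2CCN(C(c3ccccc3)c3ccc(Cl)cc3)CC2)c1` gives 5660 nM

In this assay, compound 3 (5660 nM) lies within the scatter of both compound 1 (5890 nM) and compound 2 (3330 nM), so the three values form one band.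

The next compound is compound 4 `CN(C)CCN(C)c1ccc(C#N)c(CN2CCN([C@@H](c3ccccc3)c3ccc(Cl)cc3)CC2)c1`. The change is the two compounds have the same atoms and bonds; at least one stereo element is drawn with a configuration in one of them and without one in the other: 1 of 1 stereo elements differ; a stereocentre at a saturated chain carbon is drawn without a configuration in compound 3 and S in compound 4, so the stereocentre at a saturated chain carbon, drawn without a configuration in compound 3, is drawn S in compound 4.

Within the data shown here, only one measured step bears on this, and only indirectly: a 1.7-fold higher number from compound 2 to compound 3 (0.23 log units; within the scatter). It places hydrogen in place of chloro on an aromatic carbon and leaves the configuration untouched. Among the measured compounds shown here, no measured pair tests the configuration itself, so no direction can be assigned, and no step beyond the scatter is expected.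

The expected step is a 1.0-fold lower number from compound 3 to compound 4 (0.01 log units; within the scatter).

Compound 4 is expected at 5500 nM, with an estimated range from 3300 nM to 9000 nM.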

Compound 4, half-maximal cytotoxic concentration: 8780 nM
Estimate against measurement, compound 4: 1.6-fold (0.20 log units) below, within the range that was stated.
By their numbers in this assay, from the lowest: compounds 2, 3, 1 and 4 (each within the scatter of the next, the first and the last beyond it).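

this assay gives a 1.6-fold higher number from compound 3 to compound 4 (0.19 log units; within the scatter), the first reading at this stereocentre, since compounds 1, 2 and 3 carry no drawn configuration there. Drawing the saturated chain carbon as S therefore does not separate compound 4 from compound 3 in this read-out, and tolerance in these cells shows no measurable dependence on that drawing. The step cannot be taken as a comparison of S with R, and its interpretation is limited by one fact: the fact that one of compounds 3 and 4 is drawn with a defined configuration and the other without, at the place where they differ

Open, from the compounds shown here alone, is how the R configuration at the same carbon would compare with the S configuration of compound 4. Also open, going by these compounds, is whether a methoxy group in place of chloro on the aromatic carbon would keep the S compound within the same band.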